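The compounds below may be only part of what the source reports. "The series", "measured", "known", "first", "only" and "open" are said of these compounds alone.

Among the measured compounds shown here, in a physicochemical assay for solubility, read by HPLC, at pH 7.4 (a lower number here means a less soluble compound, a higher number a more soluble compound), compound 1 `Cc1[nH]c2ccccc2c(=O)c1Cc1ccccc1` gives 10000 nM, the higher of the two actual numbers so far. Compound 2 `COc1ccc2[nH]c(C)c(Cc3ccccc3)c(=O)c2c1` gives 2000 nM. Compound 3 `Cc1[nH]c2ccc(Cl)cc2c(=O)c1Cc1ccccc1` gives < 2000 nM, which is a limit of this assay and not a number. Compound 4 `COc1cccc2c(=O)c(Cc3ccccc3)c(C)[nH]c12` is still unmeasured. It differs from compound 1 by methoxy in place of hydrogen on an aromatic carbon. For the measured compounds named here, two measured steps bear on this change: methoxy gave a 5.0-fold lower number from compound 1 to compound 2 (0.70 log units; beyond the scatter), and chloro gave an at least 5.0-fold lower number from compound 1 to compound 3 (0.69 log units; beyond the scatter). Both point downward, so a drop of similar size is expected, a 3.3-fold lower number from compound 1 to compound 4 (0.52 log units; beyond the scatter). For compound 4 the estimated value is 3000 nM, with an expected range of 1000 nM to 8000 nM.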

Compound 4, solubility: > 20000 nM
Compound 4: no number, only a limit; the forecaster's own chance of this, stated with the estimate: 25%; at least 6.6-fold (0.82 log units) between middle value and limit.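

In this assay compound 4 gives > 20000 nM, which is a limit and not a number. The same swap of hydrogen for methoxy gives a 5.0-fold lower number from compound 1 to compound 2 (0.70 log units; beyond the scatter), but an at least 2.0-fold higher number from compound 1 to compound 4 (0.30 log units; that floor lies within the scatter), so with methoxy ortho to a fused ring and meta to a fused ring, the step does not follow the downward direction seen with compound 2. As far as these compounds go, the full size of this step stays unknown because the value is a limit: the limit of > 20000 nM in this assay, at which 1 of the 4 values shown sits. The compounds shown leave open whether another group at this place, such as an amine or a carboxylic acid, would give a step in the same direction.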